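The source may report more compounds than this note shows. Statements on the series, on what has been measured and on what is new or still open speak of the compounds shown alone.

Compound 1 `CCC(C(=O)NCc1ccccc1)N1C(=O)CCC1=O` is the reference point of this small set. In a functional assay on the whole organism (strain Albino Swiss CD1) with Mus musculus as the target (a higher number here means that more compound is needed for the effect, a lower number that less compound is needed), compound 1 gives 90.3 mg/kg. Its closest neighbour is compound 2 `CCC(C(=O)NCc1ccccc1Cl)N1C(=O)CCC1=O`, which in this assay gives 76.4 mg/kg; the two values lie within the usual scatter of each other, so compound 1 stands alongside compound 2 rather than apart from it. Compound 3 `CCC(C(=O)NCc1ccccc1C(F)(F)F)N1C(=O)CCC1=O` carries a trifluoromethyl group on the same ring, but in this assay compound 3 gives "not determined" (no result reported), so it adds no number to the picture.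

The compound under consideration is compound 4 `CCC(C(=O)NCc1ccc(C(F)(F)F)cc1)N1C(=O)CCC1=O`. Its difference from compound 1 is trifluoromethyl in place of hydrogen on an aromatic carbon. Among the measured compounds shown here, the only measured step that touches the same ring is a 1.2-fold lower number from compound 1 to compound 2 (0.07 log units; within the scatter), where chloro replaced hydrogen on an aromatic carbon; that change did not move the number beyond the scatter. For the measured compounds named here, for a trifluoromethyl group on this ring no measured step exists, and compound 3 offers no value to compare. The expectation therefore rests on a single within-scatter step, and the expected step of a 1.1-fold lower number from compound 1 to compound 4 (0.05 log units; within the scatter) is none beyond the scatter. Compound 4 is estimated to give 80 mg/kg in this assay, within a range from 40 mg/kg to 160 mg/kg.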

Compound 4, dose for half-maximal effect: 80.4 mg/kg
For compound 4 the middle estimate is 1.0-fold (0.00 log units) below the measured one; measured number inside the range.
By their numbers in this assay, from the lowest: compounds 2, 4 and 1 (each within the scatter of the next).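

In this assay, among the compounds shown here, the new step, a 1.1-fold lower number from compound 1 to compound 4 (0.05 log units; within the scatter), gives the first reading for trifluoromethyl on this ring, since compound 3 carries the same group but has no number. It shows that putting this group of 4 heavy atoms in place of a hydrogen, on an aromatic carbon para to a large group, leaves the dose needed within the usual scatter of compound 1. Until now the only readable change on the ring was the swap to chloro in compound 2, so the ring has now accepted a second, larger substituent without any measurable shift, although no measurement shown here explains why the number holds steady.

Still open, on these data alone, is whether a group of another kind at this same place, such as an amine or a carboxylic acid, would move the number beyond the scatter, or whether this place simply has little influence on the dose in the mouse. Also open, as far as these compounds go, is what trifluoromethyl does at the place it occupies in compound 3, and whether a longer chain in place of the ethyl group on the shared core would matter more than any change on the ring.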